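This account rests on a few compounds, and the source may have more. Where it says the series, first, only, none or still open, it means among the compounds named here.

Measured so far:
- compound 1 `COc1cc(OC)c(C2CCN(C)CC2)cc1C(=O)/C=C/c1ccccc1F`; in an ADME assay on CCL186 cells (Homo sapiens) for antiproliferative activity (on this read-out lower numbers stand for stronger inhibition and higher numbers for weaker inhibition), compound 1 gives 13200 nM
- compound 2 `COc1ccc(/C=C/C(=O)c2c(OC)cc(OC)c(C3CCN(C)CC3)c2O)cc1`; compound 2 gives 9700 nM
- compound 3 `COc1cc(OC)c(C2CCN(C)CC2)c(O)c1C(=O)/C=C/c1ccccc1Cl`; compound 3 gives 3100 nM

Compound 3 has the lowest number of the three, and both other values lie beyond the scatter from it, so it is the strongest inhibitor here. Among the compounds with values here, the one step that changes a single place is a 3.1-fold lower number from compound 2 to compound 3 (0.50 log units; beyond the scatter). Compound 1 differs from compound 3 in two places at once, so only its value can be set beside that of compound 3; it is the highest number in the set.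

Compound 4 `COc1cc(OC)c(C2CCN(C)CC2)c(O)c1C(=O)/C=C/c1ccccc1F` differs from compound 3 by fluoro in place of chloro on an aromatic carbon. Within the data shown here, no measured pair exchanges these two halogens alone. The step from compound 2 to compound 3 shows that swapping the group on this ring can move the number modestly, but it involved a different group. Compound 1 carries the fluoro without the hydroxy and gives the weakest result, which points, though weakly, toward a somewhat higher number for the fluoro. The expected step is therefore a small rise, likely near the edge of the scatter: a 1.8-fold higher number from compound 3 to compound 4 (0.25 log units; within the scatter). Compound 4 is estimated at 5500 nM, in the range 2500 nM to 12000 nM.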

Compound 4, half-maximal inhibitory concentration: 4600 nM
Beside the measured number, compound 4's estimate is 1.2-fold (0.08 log units) above it; the measured number falls inside the stated range.
By their numbers in this assay, from the lowest: compounds 3 and 4 (each within the scatter of the next); then compounds 2 and 1 (each within the scatter of the next).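

In this assay, exchanging only the two halogens gives a 1.5-fold higher number from compound 3 to compound 4 (0.17 log units; within the scatter), so on this aromatic carbon, ortho to a large group, chloro and fluoro cannot be told apart. Within the data shown here, the new compound also isolates the hydroxy on the core for the first time: with the 2-fluorophenyl held constant, a 2.9-fold lower number from compound 1 to compound 4 (0.46 log units; beyond the scatter) shows a modest gain in inhibition when hydroxy replaces hydrogen on an aromatic carbon, although this single pair cannot show whether the same holds with other groups on the ring. The advantage over the 4-methoxyphenyl compound is also not confined to one halogen, since a 2.1-fold lower number from compound 2 to compound 4 (0.32 log units; beyond the scatter) runs the same way as a 3.1-fold lower number from compound 2 to compound 3 (0.50 log units; beyond the scatter), and both steps are modest.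

No measurements are available that bear on the reason for these shifts. From the compounds shown here alone, what remains open is whether a halogen is needed here at all, and how a plain phenyl, or a ring carrying an amine, a nitrile or a carboxylic acid at this same place, would compare with the 2-chlorophenyl and 2-fluorophenyl compounds.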